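From Amino Hydroxy Chain to Piperidinyl Chain

This account rests on a few compounds, and the source may have more. Where it says the series, first, only, none or still open, it means among the compounds named here.

Of the compounds shown here, three built on one shared core have been measured in a functional assay on the whole organism (B cells) with Mus musculus as the target; a lower number here means a smaller maximal response, a higher number a larger maximal response. Compound 1 `N#Cc1ccc(Cn2c(=O)n(C3OC(CO)[C@@H](O)[C@H]3O)c3nc(N)nc(O)c32)cc1` gives 50%. Compound 2 `Nc1nc(O)c2c(n1)n(C1OC(CO)[C@@H](O)[C@H]1O)c(=O)n2Cc1ccc([N+](=O)[O-])cc1` gives 147%. Compound 3 `NCC(O)Cn1c(=O)n(C2OC(CO)[C@@H](O)[C@H]2O)c2nc(N)nc(O)c21` gives 110%. Among these three numbers compound 3 stands second highest: the step of a number 37 percentage points lower from compound 2 to compound 3 (beyond the scatter) separates it from the nearest value, and the step of a number 60 percentage points higher from compound 1 to compound 3 (beyond the scatter) from the furthest.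

Compound 4 `Nc1nc(O)c2c(n1)n(C1OC(CO)[C@@H](O)[C@H]1O)c(=O)n2CCN1CCCCC1` differs from compound 3 at a single place: (piperidin-1-yl)methyl in place of 2-amino-1-hydroxyethyl on a saturated chain carbon bound to an aromatic nitrogen. Two of the measured steps alter this same saturated chain carbon bound to an aromatic nitrogen, and both were large, namely a number 60 percentage points higher from compound 1 to compound 3 (beyond the scatter) and a number 37 percentage points lower from compound 2 to compound 3 (beyond the scatter). Groups at this place therefore move the maximal response considerably. Among the compounds with values here, none of the measured changes, however, brings a ring to this place, so the direction of the new step is open. A step of some size, beyond the scatter in either direction, is the likeliest outcome. Taking the middle of the measured values as the guide, compound 4 is expected to give 100%, within 55% to 150%. That estimate means a step of a number 10 percentage points lower from compound 3 to compound 4 (within the scatter), expected rather than measured.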

Compound 4, largest response reached (reported as maximal response), in percent of the reference or control that the assay uses: 0%
For compound 4 the middle estimate is 100 percentage points above the measured one; the whole stated range lies above it.
By their numbers in this assay, from the lowest: compound 4; then compound 1; then compound 3; then compound 2.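

In this assay the 2-(piperidin-1-yl)ethyl group leaves no response at all, with a number 110 percentage points lower from compound 3 to compound 4 (beyond the scatter) and a number 147 percentage points lower from compound 2 to compound 4 (beyond the scatter) and also a number 50 percentage points lower from compound 1 to compound 4 (beyond the scatter) in the same run of comparisons. The earlier groups at this saturated chain carbon bound to an aromatic nitrogen only moved the response up or down, whereas this change shows that a single group here can remove it, and compound 4 now stands lowest of the four. The data shown offer nothing that explains this drop.

As far as these compounds go, the change removes the hydroxy and the primary amine and brings in the piperidine ring all at once, so which of these matters remains open. A 2-(diethylamino)ethyl chain or a 2-(morpholin-4-yl)ethyl chain at this place would help to separate the ring from the amine.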